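The compounds below may be only part of what the source reports. "The series", "measured", "known", "first", "only" and "open" are said of these compounds alone.

compound 1 `CCCOc1ccc(-c2cc(=O)c3c(o2)C(CC)(CC)C(=O)C(CC)=C3O)cc1`: > 50.5 uM, a limit.
compound 2 `CCC1=C(O)c2c(oc(-c3ccc(OC(F)(F)F)cc3)cc2=O)C(CC)(CC)C1=O`: 36.5 uM.
compound 3 `CCC1=C(O)c2c(oc(-c3ccc(SC)cc3)cc2=O)C(CC)(CC)C1=O`: > 52.1 uM, a limit.

All three were measured in a functional assay on KB cells (Homo sapiens) for antiproliferative activity, read by sulforhodamine B assay, with a stated time of 3 days; on this read-out higher numbers stand for an effect only at larger amounts of compound and lower numbers for an effect already at smaller amounts. Compound 3 has no number here, only the limit > 52.1 uM. The next change leads to compound 4 `CCC1=C(O)c2c(oc(-c3cccc(OC)c3)cc2=O)C(CC)(CC)C1=O`: 3-methoxyphenyl in place of 4-(methylsulfanyl)phenyl on an aromatic carbon. In words, 3-methoxyphenyl takes the place of 4-(methylsulfanyl)phenyl on an aromatic carbon, next to the ring oxygen of the shared core.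

Going by the values given here, three measured steps bear on this, each an exchange of one group on the aromatic ring. They are an at least 1.3-fold lower number from compound 1 to compound 2 (0.14 log units; that floor lies within the scatter), an at least 1.4-fold higher number from compound 2 to compound 3 (0.15 log units; that floor lies within the scatter) and a step that the two limits leave unreadable from compound 1 to compound 3. None of them is shown to exceed the scatter, and one cannot be sized at all. Among the compounds with values here, no measured compound carries a 3-methoxyphenyl group, so the transfer from these steps is loose.

Within the data shown here, the only firm anchor is compound 2 at 36.5 uM, and the expectation in this assay stays close to it. No step beyond the scatter is expected, in either direction. The expected step is an at least 1.3-fold lower number from compound 3 to compound 4 (0.11 log units; that floor lies within the scatter). A reported limit instead of a number is about as likely as a number for compound 4. For compound 4 the estimated value is 40 uM, with an expected range of 15 uM to 60 uM.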

Compound 4, concentration for half-maximal effect: 13.3 uM
Compound 4: middle estimate off by 3.0-fold (0.48 log units), on the high side; measured number below the stated range.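

In this assay, going by these compounds alone, placing 3-methoxyphenyl where compound 3 carries 4-(methylsulfanyl)phenyl, on the aromatic carbon next to the ring oxygen, gives an at least 3.9-fold lower number from compound 3 to compound 4 (0.59 log units; beyond the scatter), and this is the first step printed as beyond the scatter. The aromatic group at this carbon can therefore move the read-out by a clear margin, which the exchanges among compound 1, compound 2 and compound 3 did not show, and the move here is towards an effect at smaller amounts of compound. As far as these compounds go, the step is a floor and its true size remains unknown because compound 3 carries only a limit: the limit of > 52.1 uM in this assay, at which 1 of the 4 values shown sits.

This single exchange changes both the sulfur-bearing group for an oxygen-bearing one and the place of that group on the phenyl ring, so the compounds shown cannot tell which of the two goes with the lower number, and they give no measured property that would explain it. Also open, from the compounds shown here alone, is how this read-out responds to other groups on that phenyl ring, such as a dimethylamino group, a carboxylic acid or a longer alkoxy chain.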